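The compounds below may be only part of what the source reports. "The series", "measured", "known", "first", "only" and "open" are said of these compounds alone.

Measured in an ADME assay on Vero cells (Chlorocebus sabaeus) for cytotoxicity, read by sulforhodamine B assay, with a stated time of 3 days; a lower number here means that less compound is tolerated, a higher number that more compound is tolerated:
- compound 1 `COc1ccc(C2C(C(=O)Nc3ccc(Cl)cc3)=C(C)NC(C)=C2C(=O)Nc2ccc(Cl)cc2)cc1`: 20 ug/mL
- compound 2 `COc1cc(C2C(C(=O)Nc3ccc(Cl)cc3)=C(C)NC(C)=C2C(=O)Nc2ccc(Cl)cc2)ccc1O`: 250 ug/mL
- compound 3 `CC1=C(C(=O)Nc2ccc(Cl)cc2)C(c2cccc([N+](=O)[O-])c2)C(C(=O)Nc2ccc(Cl)cc2)=C(C)N1`: 26 ug/mL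

Compound 1 sits at the low end of these numbers, and compound 3 stays within the scatter of it. Compound 4 `CC1=C(C(=O)Nc2ccc(Cl)cc2)C(c2cccc(Cl)c2)C(C(=O)Nc2ccc(Cl)cc2)=C(C)N1` carries 3-chlorophenyl in place of 4-methoxyphenyl on a saturated ring carbon. Within the data shown here, the closest precedent is the change to 3-nitrophenyl in compound 3, which gave a 1.3-fold higher number from compound 1 to compound 3 (0.11 log units; within the scatter). The large 13-fold higher number from compound 1 to compound 2 (1.10 log units; beyond the scatter) came with 4-hydroxy-3-methoxyphenyl, and compound 4 has no such hydroxy group. No shift beyond the scatter is therefore expected in this assay, and the expected result is a 1.1-fold higher number from compound 1 to compound 4 (0.04 log units; within the scatter). The estimated value for compound 4 is 22 ug/mL, with an expected range of 10 ug/mL to 50 ug/mL.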

Compound 4, half-maximal cytotoxic concentration: 12 ug/mL
Compound 4: the middle estimate sits 1.8-fold (0.26 log units) above what was measured, within the range that was stated.
By their numbers in this assay, from the lowest: compounds 4, 1 and 3 (each within the scatter of the next, the first and the last beyond it); then compound 2.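

In this assay the 3-chlorophenyl of compound 4 stays within the scatter of the 4-methoxyphenyl of compound 1 (a 1.7-fold lower number from compound 1 to compound 4 (0.22 log units; within the scatter)), yet chloro in place of nitro is a modest step beyond it (a 2.2-fold lower number from compound 3 to compound 4 (0.34 log units; beyond the scatter)). The large gap to the 4-hydroxy-3-methoxyphenyl group (a 21-fold lower number from compound 2 to compound 4 (1.32 log units; beyond the scatter)) leaves compound 2 alone at the high end among these four compounds. Nothing available explains these differences.

From the compounds shown here alone, it remains open whether a lone hydroxy group, an amine or a carboxylic acid on this phenyl ring would give a similarly high number.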